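The source may report more compounds than this note shows. Statements on the series, on what has been measured and on what is new or still open speak of the compounds shown alone.

Compound 1 (`O=C(c1ccc(F)cc1)N(N=C1C(Cl)=C(Cl)C(Cl)=C1Cl)C(=O)c1ccc(F)cc1`): 300 nM
Compound 2 (`C#CC(C)(C)OC(=O)NN=C1C(Cl)=C(Cl)C(Cl)=C1Cl`): "not determined" (no result reported)

The series is read in a functional assay on MM1.S cells (Homo sapiens) for cytotoxicity, read by MTT assay, with a stated time of 48 h; a lower number here means a stronger inhibitor, a higher number a weaker inhibitor. Compound 2 has no single number there: the entry for compound 2 is "not determined" (no result reported), so compound 2 cannot be placed relative to compound 1 and gives no starting value. The next compound for testing is compound 3 (`O=C(NN=C1C(Cl)=C(Cl)C(Cl)=C1Cl)c1ccccc1`). The structural change is phenyl in place of (1,1-dimethylprop-2-yn-1-yl)oxy on a carbonyl carbon. For the measured compounds named here, no step can be sized from compound 2, so any expectation has to rest on the only number available, compound 1 at 300 nM. Against that value, no shift beyond the usual scatter of this assay is expected, and no direction can be argued, so the range is kept wide. For compound 3 the estimated value is 400 nM, with an expected range from 100 nM to 1500 nM.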

Compound 3, half-maximal inhibitory concentration: 800 nM
Beside the measured number, compound 3's estimate is 2.0-fold (0.30 log units) below it; the measured number falls inside the stated range.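

In this assay, for the compounds shown here, compound 2 has no single number, so no step to compound 3 can be read. The compounds shown leave open what phenyl in place of (1,1-dimethylprop-2-yn-1-yl)oxy on a carbonyl carbon does to the read-out. No supporting evidence bears on this result.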